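Enlarging the Small Ring on the Shared Core

The source may report more compounds than this note shows. Statements on the series, on what has been measured and on what is new or still open speak of the compounds shown alone.

Compound 1 `C[C@H](NC(=O)c1c(C(F)(F)F)nnn1Cc1ccc(C(F)(F)F)cc1)c1ccc(C(=O)O)cc1`: 225 nM
Compound 2 `C[C@H](NC(=O)c1c(-c2ccccc2)nnn1Cc1cccc(C(F)(F)F)c1)c1ccc(C(=O)O)cc1`: 23 nM
Compound 3 `C[C@H](NC(=O)c1c(C2CC2)nnn1Cc1ccc(C(F)(F)F)cc1)c1ccc(C(=O)O)cc1`: 52.1 nM

In a functional assay on CHO cells for antagonist activity at prostaglandin E2 receptor EP4 subtype (Homo sapiens), read by calcium flux, with a stated time of 15 min (on this read-out lower numbers stand for stronger inhibition and higher numbers for weaker inhibition), compound 3 gives 52.1 nM, the second highest of the three numbers. Compound 2 gives 23 nM, and compound 1 gives 225 nM. Going by the values given here, the only measured step at this place is a 4.3-fold lower number from compound 1 to compound 3 (0.64 log units; beyond the scatter), a modest move to a lower number on replacing trifluoromethyl with a small ring. Compound 4 `C[C@H](NC(=O)c1c(C2=CCCCC2)nnn1Cc1ccc(C(F)(F)F)cc1)c1ccc(C(=O)O)cc1` differs from compound 3 by cyclohex-1-en-1-yl in place of cyclopropyl on an aromatic carbon. Among the compounds with values here, compound 2 carries a phenyl at that place, but it also differs elsewhere, so its value shows only that a larger ring there is compatible with a low number. A further small step to a lower number is therefore expected in this assay , namely a 1.7-fold lower number from compound 3 to compound 4 (0.24 log units; within the scatter). Compound 4 is estimated at 30 nM, in the range 10 nM to 100 nM.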

Compound 4, half-maximal inhibitory concentration: 183 nM
Compound 4: middle estimate off by 6.1-fold (0.79 log units), on the low side; measured number outside the range, above it.
By their numbers in this assay, from the lowest: compound 2; then compound 3; then compounds 4 and 1 (each within the scatter of the next).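

In this assay, a six-membered ring at this aromatic carbon does not extend the move to a lower number seen with cyclopropyl; the change goes the other way (a 3.5-fold higher number from compound 3 to compound 4 (0.55 log units; beyond the scatter)). Cyclohex-1-en-1-yl and trifluoromethyl are not told apart at this place (a 1.2-fold lower number from compound 1 to compound 4 (0.09 log units; within the scatter)), so here a ring as such does not give a lower number. Nothing available accounts for this result. The compounds shown leave open whether cyclobutyl, or an open chain such as isopropyl, would stay close to compound 3, and how an amine at this place would read.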